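Furan-2-yl Ether Replaces the Cyanobenzyl Ether

A few compounds are considered here, and "the series" means these few. Any claim that something is new, unique, unknown or untested is made for them only; others in the source may bear on it.

Measured in a functional assay on HepG2 cells (Homo sapiens) for cytotoxicity, read by MTT assay, with a stated time of 72 h; on this read-out higher numbers stand for weaker inhibition and lower numbers for stronger inhibition:
compound 1 `CN1CCN(CCCCOc2c(OCc3ccccc3)cc(O)c3c(=O)cc(-c4ccccc4)oc23)CC1` gives 1500 nM
compound 2 `Cc1ccc(COc2cc(O)c3c(=O)cc(-c4ccccc4)oc3c2OCCCCN2CCN(C)CC2)cc1` gives 5090 nM
compound 3 `CN1CCN(CCCCOc2c(OCc3ccc(C#N)cc3)cc(O)c3c(=O)cc(-c4ccccc4)oc23)CC1` gives 590 nM

Compound 3 has the lowest number of the three; a 2.5-fold lower number from compound 1 to compound 3 (0.41 log units; beyond the scatter) and an 8.6-fold lower number from compound 2 to compound 3 (0.94 log units; beyond the scatter) both lie beyond the scatter, while a 3.4-fold higher number from compound 1 to compound 2 (0.53 log units; beyond the scatter) goes the other way. Compound 4 `CN1CCN(CCCCOc2c(OCc3ccco3)cc(O)c3c(=O)cc(-c4ccccc4)oc23)CC1` differs from compound 3 by furan-2-yl in place of 4-cyanophenyl on a saturated chain carbon bound to an oxygen on an aromatic ring. Among the compounds with values here, two measured steps bear on this change. Both involve the cyano group that now leaves: removing it from the benzyl ring raised the number, as a 2.5-fold lower number from compound 1 to compound 3 (0.41 log units; beyond the scatter) shows in reverse, and the exchange in an 8.6-fold lower number from compound 2 to compound 3 (0.94 log units; beyond the scatter) points the same way. Within the data shown here, nothing among the measured compounds shows a five-membered ring in place of the six-membered one, so that part of the change carries no guide. Compound 4 is therefore expected to give a higher number than compound 3, by about a 3.1-fold higher number from compound 3 to compound 4 (0.48 log units; beyond the scatter), in line with the loss of the cyano group. The estimate for compound 4 is 1800 nM, within a range from 700 nM to 5000 nM.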

Compound 4, half-maximal inhibitory concentration: 4110 nM
Beside the measured number, compound 4's estimate is 2.3-fold (0.36 log units) below it; measured number inside the range.
By their numbers in this assay, from the lowest: compound 3; then compound 1; then compounds 4 and 2 (each within the scatter of the next).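

The effect of furan-2-yl at this place goes beyond the loss of the nitrile: in this assay the change from 4-cyanophenyl gives a 7.0-fold higher number from compound 3 to compound 4 (0.84 log units; beyond the scatter), and the change from plain phenyl, which carries no nitrile, still gives a 2.7-fold higher number from compound 1 to compound 4 (0.44 log units; beyond the scatter). Against 4-methylphenyl, the furan-2-yl ring gives a 1.2-fold lower number from compound 2 to compound 4 (0.09 log units; within the scatter), so these two groups cannot be told apart here, although they differ in ring size and ring atoms. No measurement shown accounts for any of these differences.

On these data alone, whether a thiophen-2-yl or pyridin-3-yl ring at this place would track compound 1 or compound 4 remains open. Also open, as far as these compounds go, is whether a nitrile carried on the furan ring would bring the number back towards that of compound 3, or whether the nitrile's contribution holds only on the phenyl ring.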